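Moving the chlorine on one aryl ring of a dienone

The source may hold more compounds than are shown below. What is called first, only, known or untested is meant among the compounds shown, and "the series" means these compounds.

Compound 1, with the structure `COc1ccc(/C=C(\C)C(=O)/C=C/c2ccc(Cl)cc2)cc1`, was tested in an ADME assay on Vero cells (Chlorocebus sabaeus) for cytotoxicity, read by MTT assay, with a stated time of 72 h (a higher number here means that more compound is tolerated, a lower number that less compound is tolerated), where compound 1 gives 87000 nM. Two companions share the same general build. Compound 2 `CC/C(=C\c1ccc(Cl)cc1)C(=O)/C=C/c1cccc(OC)c1OC` gives 21800 nM in this assay, and compound 3 `CC/C(=C\c1ccc(Cl)cc1)C(=O)/C=C/c1ccc(C=O)cc1` gives 46900 nM. Among these three numbers compound 1 stands highest; the gap to compound 3 lies within the usual scatter of this assay, while the gap to compound 2 lies beyond it, so only compound 2 is clearly less well tolerated than compound 1.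

Compound 4 `COc1ccc(/C=C(\C)C(=O)/C=C/c2ccccc2Cl)cc1` has not yet been measured. It differs from compound 1 in one place: 2-chlorophenyl in place of 4-chlorophenyl on a double-bonded chain carbon bound to a double-bonded chain carbon. The chlorine simply moves to another position on the same ring, and nothing is added or removed. Among the compounds with values here, no measured pair here shows what such a move does, so the change from compound 1 to compound 4 is expected to stay within the scatter, with no clear direction, giving an expected step of a 1.2-fold lower number from compound 1 to compound 4 (0.09 log units; within the scatter). Compound 4 is therefore estimated at 70000 nM, within a range from 30000 nM to 150000 nM.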

Compound 4, half-maximal cytotoxic concentration: 74300 nM
Estimate against measurement, compound 4: 1.1-fold (0.03 log units) below, within the range that was stated.
By their numbers in this assay, from the lowest: compound 2; then compounds 3, 4 and 1 (each within the scatter of the next).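

Within the data shown here, compound 4 gives the first direct reading of this change: in this assay, 2-chlorophenyl in place of 4-chlorophenyl gives a 1.2-fold lower number from compound 1 to compound 4 (0.07 log units; within the scatter) and no clear difference between the two compounds. For this pair, then, moving the chlorine on this ring leaves the tolerated concentration unchanged within normal assay variation, though one pair cannot show whether the same holds on other cores. No supporting measurement here explains this result.

Still open, as far as these compounds go, is whether the chlorine matters at all, which plain phenyl, or a fluorine or methyl group in its place, could test. From the compounds shown here alone, it also remains open whether a more different group on this ring, such as an amine or a carboxylic acid, would move the number beyond the scatter.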